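This account rests on a few compounds, and the source may have more. Where it says the series, first, only, none or still open, it means among the compounds named here.

Of the compounds shown here, three built on one shared core have been tested in a functional assay on SW480 cells (Homo sapiens) for cytotoxicity, read by MTT assay, with a stated time of 48 h; on this read-out higher numbers stand for weaker inhibition and lower numbers for stronger inhibition. Compound 1 `Cc1cccc(Cn2cc(COc3ccc4c(=O)ccoc4c3)nn2)c1` gives 11700 nM, the highest of the two plain numbers shown. Compound 3 `O=c1ccoc2cc(OCc3cn(Cc4ccc(F)cc4)nn3)ccc12` gives 11200 nM, and the step of a 1.0-fold lower number from compound 1 to compound 3 (0.02 log units; within the scatter) falls within the scatter, so these two cannot be told apart. For compound 2 `O=c1ccoc2cc(OCc3cn(Cc4cccc(Br)c4)nn3)ccc12` the assay reports only a limit, > 100000 nM, and not a number (the limit of > 100000 nM in this assay, at which 1 of the 3 values shown sits). The step of an at least 8.5-fold higher number from compound 1 to compound 2 (0.93 log units; beyond the scatter) shows that bromo in place of methyl on that aromatic carbon weakens inhibition, and the reverse is seen in an at least 8.9-fold lower number from compound 2 to compound 3 (0.95 log units; beyond the scatter).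

Compound 4 `O=c1ccoc2cc(OCc3cn(Cc4ccc(Br)cc4)nn3)ccc12` has not yet been measured. It differs from compound 1 by 4-bromophenyl in place of 3-methylphenyl on a saturated chain carbon bound to an aromatic nitrogen. Going by the values given here, two measured steps bear on this change: the at least modest weakening in an at least 8.5-fold higher number from compound 1 to compound 2 (0.93 log units; beyond the scatter), where bromine also entered, and the unchanged result in a 1.0-fold lower number from compound 1 to compound 3 (0.02 log units; within the scatter), where a halogen entered at the same place on the ring as here. Since the bromine in compound 4 sits where the fluorine of compound 3 sat, the strong loss seen for compound 2 may not carry over fully, so a modest weakening is expected, a 2.1-fold higher number from compound 1 to compound 4 (0.33 log units; beyond the scatter). Compound 4 is estimated at 25000 nM, between 8000 nM and 100000 nM.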

Compound 4, half-maximal inhibitory concentration: 37500 nM
Compound 4: middle estimate off by 1.5-fold (0.18 log units), on the low side; measured number inside the range.
By their numbers in this assay, from the lowest: compounds 3 and 1 (each within the scatter of the next); then compound 4. At a limit, above all of these: compound 2.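

In this assay, the identity of the halogen turns out to matter: a 3.3-fold higher number from compound 3 to compound 4 (0.52 log units; beyond the scatter), whereas compound 3 alone had suggested that a halogen at this place on the ring changes nothing relative to the methyl-bearing compound 1. Replacing 3-methylbenzyl with 4-bromobenzyl is also a real loss and not a neutral swap, with a 3.2-fold higher number from compound 1 to compound 4 (0.51 log units; beyond the scatter), so the fluorine of compound 3 cannot stand for halogens in general. Where the bromine sits counts as well, as an at least 2.6-fold lower number from compound 2 to compound 4 (0.42 log units; beyond the scatter) shows, and this step gives only a minimum size since compound 2 stands at a limit and not at a number: the limit of > 100000 nM in this assay, at which 1 of the 4 values shown sits.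

The compounds shown do not tell where a 4-chlorobenzyl or 4-methylbenzyl group would fall, or whether a 3-fluorobenzyl group would lose as much as the 3-bromobenzyl group of compound 2. They also give no reading for an amine or a carboxylic acid on this ring, and they cannot say why bromine changes the result.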